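This account rests on a few compounds, and the source may have more. Where it says the series, first, only, none or still open, it means among the compounds named here.

Measured so far in an assay on HEK293 cells for agonist activity at Toll-like receptor 8 (Homo sapiens), read by spectrophotometry; a lower number here means that less compound is needed, a higher number that more compound is needed for the effect:
- compound 1 `CCCCNc1nc(N)nc(C)c1CCCN1C(=O)c2ccccc2C1=O`: 453 nM
- compound 2 `CCCCNc1nc(N)nc(C)c1C#CCN1CCCCC1`: 3790 nM
- compound 3 `CCCCNc1nc(N)nc(C)c1CC`: 1660 nM

All three share one core and differ only in the chain carried on it. Compound 3, with the shortest chain, gives the second highest number of the three in this assay. Its nearest neighbour is compound 2, whose number is higher by a margin beyond the usual scatter; the furthest is compound 1, whose number is lower by a wider margin, also beyond the scatter. Among the compounds with values here, no single-point step between measured compounds is available, so the effect of lengthening or decorating the chain can only be read loosely from these three values: the longest chain, in compound 1, goes with the lowest number.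

Compound 4 `CCCCNc1nc(N)nc(C)c1CCC(C)(C)O` is the next point. It differs from compound 3 by 1-hydroxy-1-methylethyl in place of hydrogen on a saturated chain carbon, two bonds along the chain from an aromatic carbon.

The chain in compound 4 thus ends in a group of modest size, shorter than the chain of compound 1 and without a ring. On the values of compound 1 and compound 3, a modest downward step is expected, from compound 3 to compound 4 in this assay of about a 2.2-fold lower number from compound 3 to compound 4 (0.35 log units; beyond the scatter), though a result within the scatter cannot be ruled out. Compound 4 is expected to give about 750 nM, with a range from 200 nM to 2800 nM.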

Compound 4, half-maximal effective concentration: 3140 nM
The estimate for compound 4 lay 4.2-fold (0.62 log units) below the measured number, outside the stated range (above it).
By their numbers in this assay, from the lowest: compound 1; then compounds 3, 4 and 2 (each within the scatter of the next, the first and the last beyond it).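

In this assay, within the data shown here, the replacement of hydrogen by 1-hydroxy-1-methylethyl on a saturated chain carbon, two bonds along the chain from an aromatic carbon, gives a 1.9-fold higher number from compound 3 to compound 4 (0.28 log units; within the scatter) and so provides the first single-place reading. This position therefore accepts a group of 4 heavy atoms, with 1 hydrogen-bond donor and 1 hydrogen-bond acceptor, without a shift that can be told apart from the scatter. Extending ethyl to 3-hydroxy-3-methylbutyl does not by itself bring the number toward that of compound 1, which gives 453 nM in this assay, so the loose link between chain length and a low number does not hold for compound 4. No measurement bears on the reason for this result.

The hydroxyl and the two methyl groups of the new chain end cannot be weighed separately here, and a plain 3-methylbutyl chain would be needed to isolate the part played by the hydroxyl. On these data alone, it also remains open whether a primary amine or a carboxylic acid at the end of this saturated chain would move the number beyond the scatter.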